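Chloroacetamide on the uracil-type core of compound 2

A few compounds are considered here, and "the series" means these few. Any claim that something is new, unique, unknown or untested is made for them only; others in the source may bear on it.

Measured so far:
compound 1 `Cc1cc(=O)[nH]c(=O)n1COC(CO)CO` — > 100000 nM
compound 2 `O=c1ccn(COC(CO)CO)c(=O)[nH]1` — > 100000 nM
compound 3 `CC(C)(C)OC(=O)NCCNCC(=O)Nc1c[nH]c(=O)[nH]c1=O` — 50000 nM

Notes. In a functional assay on MIA PaCa-2 cells (Homo sapiens) for inhibition, read by MTT assay, with a stated time of 72 h (on this read-out higher numbers stand for weaker inhibition and lower numbers for stronger inhibition), compound 1 gives > 100000 nM, which is a limit of the assay and not a number. Compound 2 `O=c1ccn(COC(CO)CO)c(=O)[nH]1` likewise sits at a limit in this assay, > 100000 nM, and so no number is known for it. Within the data shown here, the single one-place step measured, a step that the two limits leave unreadable from compound 1 to compound 2, runs between two such limits and gives no readable size, as the limit of > 100000 nM in this assay, at which 2 of the 3 values shown sit, shows. Among the measured compounds shown here, compound 3 `CC(C)(C)OC(=O)NCCNCC(=O)Nc1c[nH]c(=O)[nH]c1=O` is the only measured compound with a number, 50000 nM; no single-place step connects it to compound 2, so the two values can only be set side by side.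

The change to compound 4 `O=C(CCl)Nc1cn(COC(CO)CO)c(=O)[nH]c1=O` is ((chloromethyl)carbonyl)amino in place of hydrogen on an aromatic carbon. For the measured compounds named here, none of the measured steps bears on this change directly; the one step recorded is unreadable, and compound 3 carries a different acylamino group on a different core. Compound 3, with an acylamino group on the shared core, shows 50000 nM, which is the only hint that such a group can bring a value into the measurable range. The step of an at least 3.3-fold lower number from compound 2 to compound 4 (0.52 log units; beyond the scatter) is therefore expected to be toward stronger inhibition, though compound 2 stands at a limit and the size cannot be anchored. Compound 4 is estimated at 30000 nM, between 5000 nM and 150000 nM, with a real chance that this assay again reports only a limit.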

Compound 4, half-maximal inhibitory concentration: 18000 nM
Compound 4: the middle estimate sits 1.7-fold (0.22 log units) above what was measured, and the stated range covers the measured number.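

In this assay, among these compounds, ((chloromethyl)carbonyl)amino in place of hydrogen on this aromatic carbon gives an at least 5.5-fold lower number from compound 2 to compound 4 (0.74 log units; beyond the scatter), the only readable step so far. It shows that a change at this position, two atoms from the ring nitrogen, can bring the core of compound 2 into the measurable range, which the unreadable step between the two limit compounds could not show. Compound 2 stands at a limit, so the step fixes only a bound on the size of the change, not the size itself, because its starting point is not a number: the limit of > 100000 nM in this assay, at which 2 of the 4 values shown sit.

Open, on these data alone, is whether the chlorine takes part in this step, a question that a comparison of compound 4 with an acetylamino group or a free amine on the same carbon would address. Also open, as far as these compounds go, is how the value responds to a longer chain on the carbonyl at this position, and compound 3 differs from compound 4 in more than one place, so it cannot answer this.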